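The compounds below may be only part of what the source reports. "The series", "measured", "known", "first", "only" and "open" are said of these compounds alone.

Measured compounds:
Compound 1, `CCOc1cc(CN2CCC(NC(=O)c3ccc(NC(C)C)nc3)CC2)cc(OCC)c1F`: 3.39
Compound 2, `CCOc1cc(CN2CCC(NC(=O)c3cncc(C)c3)CC2)cc(OCC)c1Cl`: 3.43
Compound 3, `CCOc1cc(CN2CCC(NC(=O)c3ccc(NC)nc3)CC2)cc(OCC)c1F`: 2.66

In a physicochemical assay for lipophilicity, read by spectrophotometry, measured as octanol-water partition, at pH 7.4 (a higher number here means a more lipophilic compound, a lower number a more polar compound), compound 3 gives the lowest of the three numbers; compound 1 stands nearest to it and compound 2 furthest, both beyond the scatter. Compound 4, `CCOc1cc(CN2CCC(NC(=O)c3cncc(C)c3)CC2)cc(OCC)c1F`, has not yet been measured in this assay. It differs from compound 3 in one place: 5-methylpyridin-3-yl in place of 6-(methylamino)pyridin-3-yl on a carbonyl carbon.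

Among the measured compounds shown here, only one measured step touches the same part of the molecule, and it is a different change: a number 0.73 log units lower from compound 1 to compound 3 (beyond the scatter). That step shows the number responding to the substituent on the ring nitrogen, but it does not cover the exchange of the whole aromatic group. Compound 2 carries the same 5-methylpyridin-3-yl group as compound 4 on a core that differs from it only in the halogen, and compound 2 gives 3.43. Taken together, these numbers point to compound 4 lying above compound 3 in this assay, with the step expected to be beyond the scatter.

The estimate for compound 4 in this assay is 3.2, within 2.8 to 3.6. This corresponds to an expected step of a number 0.54 log units higher from compound 3 to compound 4 (beyond the scatter).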

Compound 4, distribution coefficient: 2.9
Compound 4: the middle estimate sits 0.30 log units above what was measured; the measured number falls inside the stated range.
By their numbers in this assay, from the lowest: compounds 3 and 4 (each within the scatter of the next); then compounds 1 and 2 (each within the scatter of the next).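

In this assay, among the compounds shown here, the first exchange of the whole group on the carbonyl carbon gives a number 0.24 log units higher from compound 3 to compound 4 (within the scatter) and so does not separate 5-methylpyridin-3-yl from 6-(methylamino)pyridin-3-yl, whereas the same exchange starting from 6-(isopropylamino)pyridin-3-yl gives a number 0.49 log units lower from compound 1 to compound 4 (beyond the scatter) and does separate the two groups. The number therefore depends on which aminopyridinyl group is replaced, and the earlier step on the nitrogen substituent alone could not show this. A second site also comes into view: fluoro in place of chloro on an aromatic carbon, with 5-methylpyridin-3-yl held constant, gives a number 0.53 log units lower from compound 2 to compound 4 (beyond the scatter) and so shows that the halogen alone can move the number beyond the scatter, and no information is available here to explain any of these steps.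

From the compounds shown here alone, the halogen step rests on this single pair, so it remains open whether it would hold with 6-(methylamino)pyridin-3-yl or 6-(isopropylamino)pyridin-3-yl on the carbonyl carbon. Also open, going by these compounds, is how an ethylamino or a dimethylamino group on the pyridine, or a bromo group in place of the halogen, would read in this assay.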